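The source may report more compounds than this note shows. Statements on the series, on what has been measured and on what is new or still open speak of the compounds shown alone.

Three compounds share one core and differ only in the group on the aromatic carbon. In an assay on CHO-K1 cells with adenosine receptor A1 (Homo sapiens) as the target (a higher number here means that more compound is needed for the effect, a lower number that less compound is needed), compound 1 `CCOC(=O)c1nn(-c2ccc(O)cc2)c(=O)c2c(N)scc12` gives 7100 nM. Compound 2 `CCOC(=O)c1nn(-c2ccc(C(F)(F)F)cc2)c(=O)c2c(N)scc12` gives 8400 nM in this assay, and compound 3 `CCOC(=O)c1nn(-c2ccc([N+](=O)[O-])cc2)c(=O)c2c(N)scc12` gives 13000 nM. Compound 3 holds the highest of the three numbers, yet every step toward it stays within the scatter: a 1.8-fold higher number from compound 1 to compound 3 (0.26 log units; within the scatter), a 1.5-fold higher number from compound 2 to compound 3 (0.19 log units; within the scatter), and likewise a 1.2-fold higher number from compound 1 to compound 2 (0.07 log units; within the scatter). Compound 4 `CCOC(=O)c1nn(-c2ccc(OC(C)=O)cc2)c(=O)c2c(N)scc12` carries acetoxy in place of nitro on an aromatic carbon. All three measured steps at this aromatic carbon, across groups of quite different kind, stayed within the scatter, so for compound 4 no step beyond the scatter is expected in this assay, and the expected step is a 1.4-fold lower number from compound 3 to compound 4 (0.16 log units; within the scatter). Compound 4 is therefore estimated at 9000 nM, with a range from 4000 nM to 20000 nM.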

Compound 4, half-maximal effective concentration: 2500 nM
Estimate against measurement, compound 4: 3.6-fold (0.56 log units) above, and the stated range ends above it.
By their numbers in this assay, from the lowest: compound 4; then compounds 1, 2 and 3 (each within the scatter of the next).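

For the compounds shown here, at this aromatic carbon, the group can matter in this assay after all: acetoxy brings the first steps beyond the scatter, with a 5.2-fold lower number from compound 3 to compound 4 (0.72 log units; beyond the scatter) when it replaces nitro and a 3.4-fold lower number from compound 2 to compound 4 (0.53 log units; beyond the scatter) when it replaces trifluoromethyl. Acetyl in place of hydrogen on the oxygen has a similar outcome, with a 2.8-fold lower number from compound 1 to compound 4 (0.45 log units; beyond the scatter) in the same direction. Nothing available explains these steps. Whether the lower number is particular to acetoxy remains open, as the compounds shown do not tell how a longer ester such as propanoyloxy or an amide such as acetamido would behave.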